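Methoxy for dipropylamino: compound 3 to compound 4

The source may hold more compounds than are shown below. What is called first, only, known or untested is meant among the compounds shown, and "the series" means these compounds.

In an ADME assay on NIH3T3 cells (Mus musculus) for cytotoxicity (a higher number here means that more compound is tolerated, a lower number that less compound is tolerated), compound 3 `CCCN(CC#Cc1cc2c(Nc3ccc(OCc4cccc(F)c4)c(Cl)c3)ncnc2s1)CCC` gives 2.2 uM, the lowest number in the series. Compound 1 `CCOC(=O)CN(C)CC#Cc1cc2ncnc(Nc3ccc(OCc4cccc(F)c4)c(Cl)c3)c2s1` gives 52 uM, the nearest value and beyond the scatter. Compound 2 `Fc1cccc(COc2ccc(Nc3ncnc4cc(C#CC5CCCC5)sc34)cc2Cl)c1` sits at a limit of the assay, > 100 uM.

Compound 4 `COCC#Cc1cc2c(Nc3ccc(OCc4cccc(F)c4)c(Cl)c3)ncnc2s1` carries methoxy in place of dipropylamino on a saturated chain carbon bound to a triple-bonded carbon. For the measured compounds named here, the one measured step bearing on this, an at least 1.9-fold higher number from compound 1 to compound 2 (0.28 log units; that floor lies within the scatter), also removes an amino group, but its floor stays within the scatter. Compound 1 and compound 2 also have a core different from that shared by compound 3 and compound 4, so it is only a loose guide. A clear move to a higher number in this assay is expected, with the estimated step being an 11-fold higher number from compound 3 to compound 4 (1.06 log units; beyond the scatter). Compound 4 is estimated at 25 uM, with an expected range of 6 uM to 100 uM.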

Compound 4, half-maximal toxic concentration: 1.7 uM
The estimate for compound 4 lay 15-fold (1.17 log units) above the measured number, outside the stated range (below it).
By their numbers in this assay, from the lowest: compounds 4 and 3 (each within the scatter of the next); then compound 1. At a limit, above all of these: compound 2.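

In this assay, methoxy in place of dipropylamino on a saturated chain carbon bound to a triple-bonded carbon gives a 1.3-fold lower number from compound 3 to compound 4 (0.11 log units; within the scatter). On this core, the low tolerated concentration therefore does not depend on dipropylamino: compound 4, with no amine at this place, matches compound 3 within the scatter. Nothing shown gives a cause for this result.

As far as these compounds go, it remains open whether a carboxylic acid or a primary amine at this place would give a higher number, and whether cyclopentyl would do so on this core.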